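A few compounds are considered here, and "the series" means these few. Any claim that something is new, unique, unknown or untested is made for them only; others in the source may bear on it.

Working notes on the cytotoxicity series.

Compound 1 `O=C(Nc1cccc(OCCc2ccccn2)c1)C1CCCN(C(=O)c2cc(C(F)(F)F)cc(C(F)(F)F)c2)C1` and compound 2 `COC(=O)c1cc(-c2cccc(NC(=O)C3CCCN(C(=O)c4cc(C(F)(F)F)cc(C(F)(F)F)c4)C3)c2)co1` share one core and differ only at one aromatic carbon. In an ADME assay on PC-3 cells (Homo sapiens) for cytotoxicity, read by WST assay, tested at 100 uM (on this read-out lower numbers stand for less inhibition and higher numbers for more inhibition at the one concentration tested (going by the name of the read-out)), compound 1 gives 5%, and in this assay compound 2 gives 0%. The only step measured so far, a number 5 percentage points lower from compound 1 to compound 2 (within the scatter), is within the scatter, so the two compounds cannot be told apart on this read-out; compound 2 merely sits at the bottom of the two numbers shown, with compound 1 as its nearest neighbour.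

Compound 3 `Cn1cnnc1-c1cccc(NC(=O)C2CCCN(C(=O)c3cc(C(F)(F)F)cc(C(F)(F)F)c3)C2)c1` is the next member. Its change from compound 2 is 4-methyl-4H-1,2,4-triazol-3-yl in place of 5-(methoxycarbonyl)furan-3-yl on an aromatic carbon. Among the measured compounds shown here, the one step that bears on it is the exchange at the same aromatic carbon from compound 1 to compound 2, which was within the scatter. With only that to go on, no step beyond the scatter is expected in this assay for this exchange either, in neither direction. For compound 3 the expected value in this assay is therefore 3%, estimated to lie between -8% and 15%, which means an expected step of a number 3 percentage points higher from compound 2 to compound 3 (within the scatter).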

Compound 3, a percentage reported as inhibition, at one concentration (the size of the read-out at that concentration, not a potency): 0%
For compound 3 the middle estimate is 3 percentage points above the measured one; low and high end bracket the measured number.
By their numbers in this assay, from the lowest: compounds 2, 3 and 1 (each within the scatter of the next).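

In this assay, putting 4-methyl-4H-1,2,4-triazol-3-yl in place of 5-(methoxycarbonyl)furan-3-yl gives no change at the digits printed from compound 2 to compound 3 (within the scatter), and putting it in place of 2-(pyridin-2-yl)ethoxy gives a number 5 percentage points lower from compound 1 to compound 3 (within the scatter). The position on the aromatic carbon, meta to a large group, now carries three groups that cannot be told apart on this read-out, although the exchange from compound 2 to compound 3 goes from 9 heavy atoms to 6, from carbon and oxygen to carbon and nitrogen, and from a five-membered aromatic ring with 1 hetero atom to one with 3 hetero atoms, while the count of 3 hydrogen-bond acceptors stays the same. No supporting data on the properties of these groups are available to interpret this result.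

Going by these compounds, all three compounds sit near the bottom of the read-out at the one concentration tested, so it remains open whether any group at this carbon can produce a step beyond the scatter. An aliphatic amine or a carboxylic acid at this carbon might settle that, and the compounds shown say nothing about changes elsewhere on the shared core, such as replacing a trifluoromethyl group.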